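Swapping 4-fluorophenyl for 3-methoxyphenyl on a shared core

The source may hold more compounds than are shown below. What is called first, only, known or untested is meant among the compounds shown, and "the series" means these compounds.

Compound 1 `COc1cc(OC)c(OC)cc1/C=C/COC(=O)/C=C/c1ccc(OC)c(OC)c1`: > 300 mg/kg
Compound 2 `COc1cc(OC)c(OC)cc1/C=C/COC(=O)/C=C/c1ccc(F)cc1`: > 300 mg/kg

Both compounds were tested in a functional assay on the whole organism (strain Kunming) with Mus musculus as the target, with a stated time of 0.5 h; on this read-out lower numbers stand for an effect already at smaller amounts and higher numbers for an effect only at larger amounts of compound. In this test, compound 2 gives > 300 mg/kg. That value is a limit of the assay and not a number. Compound 2 therefore stands at the limit of > 300 mg/kg in this assay, at which 2 of the 2 values shown sit, so its place cannot be ranked against compound 1.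

The next compound is compound 3 `COc1cccc(/C=C/C(=O)OC/C=C/c2cc(OC)c(OC)cc2OC)c1`, and the change is 3-methoxyphenyl in place of 4-fluorophenyl on a double-bonded chain carbon bound to a double-bonded chain carbon. In words, 3-methoxyphenyl takes the place of 4-fluorophenyl on a double-bonded chain carbon bound to a double-bonded chain carbon.

For the measured compounds named here, only one measured step bears on this change, at the same place: a step that the two limits leave unreadable from compound 1 to compound 2. It gives no size to carry over. The closest guide is compound 1, which carries a 3,4-dimethoxyphenyl group there and gives > 300 mg/kg, also a limit. With so little to go on, no step beyond the usual scatter is expected, and another limit is the likeliest report. The expected step is a step that the limit leaves unreadable from compound 2 to compound 3. For compound 3 the estimated value is 350 mg/kg, with an expected range from 150 mg/kg to 800 mg/kg.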

Compound 3, dose for half-maximal effect: 249 mg/kg
The estimate for compound 3 lay 1.4-fold (0.15 log units) above the measured number; measured number inside the range.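

In this assay, for the compounds shown here, compound 3 gives 249 mg/kg, the only one of the three values shown that is a number and not a limit, so this shared core can give a readable dose with the right group on a double-bonded chain carbon bound to a double-bonded chain carbon. Putting 3-methoxyphenyl in place of 4-fluorophenyl gives an at least 1.2-fold lower number from compound 2 to compound 3 (0.08 log units; that floor lies within the scatter), and hydrogen in place of methoxy on an aromatic carbon gives an at least 1.2-fold lower number from compound 1 to compound 3 (0.08 log units; that floor lies within the scatter). Both figures are only the smallest step the data allow, and neither floor shows a change beyond the usual scatter, as compound 1 and compound 2 each stand at a limit of the assay and not at a number: the limit of > 300 mg/kg in this assay, at which 2 of the 3 values shown sit.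

From the compounds shown here alone, how large these two steps really are stays open, so it cannot yet be said whether 3-methoxyphenyl truly improves on either of the other two groups. Also open, going by these compounds, is what an amine or a carboxylic acid on the aromatic ring at this place would give, or how a longer chain there would change the dose.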